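This account rests on a few compounds, and the source may have more. Where it says the series, first, only, none or still open, it means among the compounds named here.

In an ADME assay for permeability, using PAMPA, with a stated time of 30 min, at pH 7.4 (on this read-out higher numbers stand for higher permeability and lower numbers for lower permeability), three compounds of a shared core have been measured. Compound 1 `COc1cccc(CNCCCNc2ccnc3cc(Cc4ccc(F)cc4)ccc23)c1O` gives 23 10^-6 cm/s; compound 2 `COc1cccc(CNCCCNc2ccnc3cc(-c4ccc(C(F)(F)F)cc4)ccc23)c1O` gives 237 10^-6 cm/s; compound 3 `COc1cccc(CNCCCNc2ccnc3cc(CC4CCCCC4)ccc23)c1O` gives 23 10^-6 cm/s. Compound 3 thus sits level with compound 1 at the digits reported, and the two together form the low end of the set, while compound 2 stands apart: a 10-fold lower number from compound 2 to compound 3 (1.01 log units; beyond the scatter).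

Compound 4 `COc1cccc(CNCCCNc2ccnc3cc(-c4cccc5ccccc45)ccc23)c1O` has not yet been measured. It differs from compound 3 in one place: naphthalen-1-yl in place of cyclohexylmethyl on an aromatic carbon. Two of the measured steps bear on this. The step of a 10-fold higher number from compound 1 to compound 2 (1.01 log units; beyond the scatter) exchanged a group bound through a saturated chain carbon for a ring set on the aromatic carbon itself, and the step of a 10-fold lower number from compound 2 to compound 3 (1.01 log units; beyond the scatter) ran the other way, replacing that ring with cyclohexylmethyl. The step of no change at the digits printed from compound 1 to compound 3 (within the scatter) shows that swapping one chain-borne ring for another left the number where it was. Compound 4 again puts an aromatic ring on the aromatic carbon, so a large rise is expected, of about the size seen for compound 2. The expected step is an 8.7-fold higher number from compound 3 to compound 4 (0.94 log units; beyond the scatter). Compound 4 is therefore estimated to give 200 10^-6 cm/s, with a range from 80 10^-6 cm/s to 450 10^-6 cm/s.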

Compound 4, apparent permeability: 237 10^-6 cm/s
Beside the measured number, compound 4's estimate is 1.2-fold (0.07 log units) below it, within the range that was stated.
By their numbers in this assay, from the lowest: compounds 1 and 3 (each within the scatter of the next); then compounds 2 and 4 (each within the scatter of the next).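

In this assay, naphthalen-1-yl in place of cyclohexylmethyl on an aromatic carbon gives a 10-fold higher number from compound 3 to compound 4 (1.01 log units; beyond the scatter), and the same group in place of 4-fluorobenzyl gives a 10-fold higher number from compound 1 to compound 4 (1.01 log units; beyond the scatter). Across these four compounds, the two rings attached straight to the aromatic carbon therefore give the high numbers and the two groups attached through a saturated chain carbon give the low numbers, with no compound going against this split. Naphthalen-1-yl in place of 4-(trifluoromethyl)phenyl gives no change at the digits printed from compound 2 to compound 4 (within the scatter), so the high number does not depend on trifluoromethyl or on a single ring, and it holds for a fused pair of aromatic rings made of carbon only.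

Nothing available explains why these groups divide in this way. On these data alone, it remains open whether a ring on the aromatic carbon must be aromatic, as a cyclohexyl group attached there would test, and whether a pyridine ring or a phenyl ring carrying a carboxylic acid would stay with compound 2 and compound 4 at the high end.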